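Adding a Bromo to Compound 3

A few compounds are considered here, and "the series" means these few. Any claim that something is new, unique, unknown or untested is made for them only; others in the source may bear on it.

Values measured in a functional assay (on this read-out lower numbers stand for stronger inhibition and higher numbers for weaker inhibition), are as follows:
- compound 1 `CC(C)=CCOc1ccc2c(c1)OC(c1ccccc1)CC2=O` gives 6070 nM
- compound 2 `COc1ccc(C2CC(=O)c3ccc(OCC=C(C)C)cc3O2)c(OC)c1` gives 8180 nM
- compound 3 `CC(C)=CCOc1cc(O)c2c(c1)OC(c1ccccc1)CC2=O` gives 7320 nM

These three values lie within the usual scatter of one another, so compound 3 stands level with compound 1 and compound 2 on these numbers, and no ranking among them can be drawn.

The next compound, compound 4 `CC(C)=CCOc1cc(O)c2c(c1)OC(c1ccccc1Br)CC2=O`, is compound 3 with bromo in place of hydrogen on an aromatic carbon, a change that turns phenyl to 2-bromophenyl. Among the measured compounds shown here, only one measured step can be compared with it: a 1.2-fold higher number from compound 1 to compound 3 (0.08 log units; within the scatter). That step brought in hydroxy rather than bromo, so it is only a loose guide. For the measured compounds named here, no measured compound carries a bromo. Given that small step, no clear shift is expected in this assay, in either direction, beyond the scatter. The expected step is a 1.2-fold lower number from compound 3 to compound 4 (0.09 log units; within the scatter), and the wide range reflects how little the data say about bromo. Compound 4 is estimated at 6000 nM, with an expected range from 2500 nM to 14000 nM.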

Compound 4, half-maximal inhibitory concentration: 3820 nM
Estimate against measurement, compound 4: 1.6-fold (0.20 log units) above, within the range that was stated.
By their numbers in this assay, from the lowest: compounds 4, 1, 3 and 2 (each within the scatter of the next, the first and the last beyond it).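

In this assay, turning the phenyl of compound 3 into the 2-bromophenyl of compound 4 gives a 1.9-fold lower number from compound 3 to compound 4 (0.28 log units; within the scatter) and so stays within the scatter, though only just. Among the compounds shown here, this change shows that the phenyl can carry a bromine atom, ortho to a large group, without a step beyond the scatter; the only earlier step, a 1.2-fold higher number from compound 1 to compound 3 (0.08 log units; within the scatter), concerned a hydroxy group elsewhere and said nothing about this ring. Nothing available explains this small step or shows what bromo does here.

On these data alone, whether a bromo on another carbon of this ring would give a step beyond the scatter remains open. So does the outcome of other groups at this same carbon, such as an amine, a carboxylic acid or a longer chain.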